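Swapping Trifluoromethyl for Chloro: Expected Permeability of Compound 3

The source may report more compounds than this note shows. Statements on the series, on what has been measured and on what is new or still open speak of the compounds shown alone.

Compound 1 `Cc1cc(NC(=O)Nc2ccc(C(F)(F)F)cc2)c2ccccc2n1` and compound 2 `Cc1cc(NC(=O)Nc2ccc([N+](=O)[O-])c(C(F)(F)F)c2)c2ccccc2n1` share one core and differ only in the groups carried by a single aromatic ring. In an ADME assay for permeability, using PAMPA, at pH 7.4 (on this read-out lower numbers stand for lower permeability and higher numbers for higher permeability), compound 1 gives 2 10^-6 cm/s, the lowest of the two numbers, while compound 2 gives 45 10^-6 cm/s, a gap well beyond the scatter. Compound 3 `Cc1cc(NC(=O)Nc2ccc(Cl)cc2)c2ccccc2n1` has not yet been measured; it differs from compound 1 in one place: chloro in place of trifluoromethyl on an aromatic carbon. Among the compounds with values here, no measured pair shows this change, so any expectation is uncertain. A small step in this assay is expected, a 1.5-fold higher number from compound 1 to compound 3 (0.18 log units; within the scatter), likely within the scatter. Compound 3 is therefore estimated at 3 10^-6 cm/s, within 0.8 10^-6 cm/s to 12 10^-6 cm/s.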

Compound 3, apparent permeability: 537 10^-6 cm/s
Estimate against measurement, compound 3: 180-fold (2.25 log units) below, and the stated range ends below it.
By their numbers in this assay, from the lowest: compound 1; then compound 2; then compound 3.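

At this position on the aromatic ring, para to a large group, chloro in place of trifluoromethyl gives a 270-fold higher number from compound 1 to compound 3 (2.43 log units; beyond the scatter) in this assay. This single change, with no ring, hydrogen-bond donor, hydrogen-bond acceptor or net charge entering or leaving, is thus enough to shift the read-out strongly. Nothing available here accounts for the size of the step.

From the compounds shown here alone, whether other groups at this place, such as methoxy, an amine or a carboxylic acid, would give a step of similar size remains open. Going by these compounds, it is also open whether the same change would act similarly on a ring that also carries a nitro group.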